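The source may hold more compounds than are shown below. What is called first, only, known or untested is meant among the compounds shown, and "the series" means these compounds.

Compound 3 `COc1ccc(C2CC2C(=O)NNc2nncc3ccccc23)cc1` is one of three compounds tested in a functional assay on U-373MG ATCC cells (Homo sapiens) for inhibition, read by MTT assay, with a stated time of 72 h; a lower number here means a stronger inhibitor, a higher number a weaker inhibitor. In that assay compound 3 gives 83000 nM, the second-highest of the three numbers. Compound 1 `CC(C)=CCC/C(C)=C/COc1ccc(C2CC2C(=O)NNC(=O)c2ccncc2)cc1` gives 84000 nM, within the scatter of compound 3, and compound 2 `O=C(NNc1nncc2ccccc12)C1CC1c1ccc(OCC(F)(F)F)cc1` gives 25000 nM. Among the compounds with values here, the only single-point step measured, a 3.3-fold higher number from compound 2 to compound 3 (0.52 log units; beyond the scatter), concerns a different position from the change now at hand. Compound 4 `CC(C)=CCC/C(C)=C/COc1ccc(C2CC2C(=O)NNc2nncc3ccccc23)cc1` differs from compound 3 by 2,6-dimethylhepta-1,5-dien-1-yl in place of hydrogen on a saturated chain carbon bound to an oxygen on an aromatic ring. Within the data shown here, no measured step covers this change; compound 1, which carries the same chain on a different core, gives a number close to compound 3, so a step of a 1.5-fold lower number from compound 3 to compound 4 (0.18 log units; within the scatter) is expected, no larger than the scatter. Compound 4 is therefore estimated at 55000 nM, between 15000 nM and 150000 nM.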

Compound 4, half-maximal inhibitory concentration: 9000 nM
Compound 4: middle estimate off by 6.1-fold (0.79 log units), on the high side, and the stated range ends above it.
By their numbers in this assay, from the lowest: compound 4; then compound 2; then compounds 3 and 1 (each within the scatter of the next).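

In this assay, putting 2,6-dimethylhepta-1,5-dien-1-yl in place of hydrogen gives a 9.2-fold lower number from compound 3 to compound 4 (0.96 log units; beyond the scatter), so this position does respond to the change on this core. The same chain also outdoes trifluoromethyl at this position, with a 2.8-fold lower number from compound 2 to compound 4 (0.44 log units; beyond the scatter). With the chain held constant, swapping the group on the amine nitrogen gives a 9.3-fold lower number from compound 1 to compound 4 (0.97 log units; beyond the scatter), so the chain's gain shows up only with the core of compound 4. Nothing here measures why these numbers shift. Going by these compounds, whether a shorter chain such as ethyl, a saturated chain such as geranyl's fully reduced form, or a chain ending in an amine would match compound 4 remains open.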